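Chloro to Fluoro on the Aromatic Ring of Compound 2

A few compounds are considered here, and "the series" means these few. Any claim that something is new, unique, unknown or untested is made for them only; others in the source may bear on it.

Compound 2 `C[C@H](c1ccc(C(=O)NCCC(=O)O)cc1)N1C(=O)C(c2cccc(Cl)c2)=N[C@]12CC[C@@H](C(C)(C)C)CC2` stands at the low end of the three numbers measured in an assay on CHO cells for displacement of a labelled ligand from Glucagon receptor (Homo sapiens), read by scintillation counting, with a stated time of 60 min (on this read-out higher numbers stand for weaker inhibition and lower numbers for stronger inhibition), where compound 2 gives 130 nM. Compound 1 `C[C@H](c1ccc(C(=O)NCCC(=O)O)cc1)N1C(=O)C(c2cccc(OC(F)(F)F)c2)=N[C@]12CC[C@@H](C(C)(C)C)CC2` gives 330 nM in this assay, and compound 3 `CC(C)(C)[C@H]1CC[C@]2(CC1)N=C(c1cccc(Cl)c1)C(=O)N2Cc1ccc(C(=O)NCCC(=O)O)cc1` gives 770 nM. The two measured steps are a 2.5-fold lower number from compound 1 to compound 2 (0.40 log units; beyond the scatter) and a 5.9-fold higher number from compound 2 to compound 3 (0.77 log units; beyond the scatter). Compound 4 `C[C@H](c1ccc(C(=O)NCCC(=O)O)cc1)N1C(=O)C(c2cccc(F)c2)=N[C@]12CC[C@@H](C(C)(C)C)CC2` differs from compound 2 by fluoro in place of chloro on an aromatic carbon. Among the compounds with values here, only the step from compound 1 to compound 2 bears on this change, since it alters the same aromatic carbon; the step from compound 2 to compound 3 concerns the saturated chain carbon and says nothing here. Within the data shown here, that one relevant step was modest, and the data hold no fluoro compound at all, so the direction rests on the single fact that chloro gave the lowest number seen. Compound 4 is therefore expected to show a modest rise, a 2.0-fold higher number from compound 2 to compound 4 (0.30 log units; within the scatter), with compound 4 estimated at 260 nM, within 110 nM to 650 nM.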

Compound 4, half-maximal inhibitory concentration: 490 nM
The estimate for compound 4 lay 1.9-fold (0.28 log units) below the measured number; low and high end bracket the measured number.
By their numbers in this assay, from the lowest: compound 2; then compounds 1, 4 and 3 (each within the scatter of the next, the first and the last beyond it).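

The new step, a 3.8-fold higher number from compound 2 to compound 4 (0.58 log units; beyond the scatter), shows that in this assay this aromatic carbon does not accept just any halogen: exchanging chloro for fluoro costs at least as much as exchanging it for trifluoromethoxy did. Fluoro and trifluoromethoxy are not separated, since a 1.5-fold higher number from compound 1 to compound 4 (0.17 log units; within the scatter), so chloro now stands apart from both groups tried at this carbon, while the other two cannot be ordered. Nothing given here accounts for the gap between chloro and fluoro.

From the compounds shown here alone, whether bromo, methyl or a nitrile at this carbon would match chloro stays open, as does the effect of any group at the other ring carbons. Also open, going by these compounds, is whether the gap between chloro and fluoro persists without the methyl on the saturated chain carbon, the form seen in compound 3.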